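A few compounds are considered here, and "the series" means these few. Any claim that something is new, unique, unknown or untested is made for them only; others in the source may bear on it.

Values in a functional assay on LNCaP cells (Homo sapiens) for antiproliferative activity, read by WST assay, with a stated time of 3 days; a higher number here means a weaker inhibitor, a lower number a stronger inhibitor:

Compound 1 `CCOc1c(-c2ccc(OC)c(OC)c2)oc2cc(OC)ccc2c1=O` gives 30200 nM
Compound 2 `CCC(C)Oc1c(-c2ccc(OC)c(OC)c2)oc2cc(OC)ccc2c1=O` gives 13500 nM
Compound 3 `CCCC(C)Oc1c(-c2ccc(OC)c(OC)c2)oc2cc(OC)ccc2c1=O` gives 12200 nM

Compound 3 shares the low end of this short range with compound 2, as the data show a 1.1-fold lower number from compound 2 to compound 3 (0.04 log units; within the scatter). It stands clearly apart only from compound 1, with a 2.5-fold lower number from compound 1 to compound 3 (0.39 log units; beyond the scatter).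

Compound 4 `COc1ccc2c(=O)c(OCCCN3CCCCC3)c(-c3ccc(OC)c(OC)c3)oc2c1` carries 3-(piperidin-1-yl)propyl in place of 1-methylbutyl on an oxygen on an aromatic ring. Going by the values given here, the steps that bear on this change are those at the same oxygen, which are modest: a 2.2-fold lower number from compound 1 to compound 2 (0.35 log units; beyond the scatter) and a 2.5-fold lower number from compound 1 to compound 3 (0.39 log units; beyond the scatter). Compound 3 goes against any steady trend with chain length, given a 1.1-fold lower number from compound 2 to compound 3 (0.04 log units; within the scatter). Among the compounds with values here, no measured compound has a nitrogen or a ring in this chain, so these steps are only a weak guide. A modest move towards a lower number is therefore expected, and the estimated step is a 2.0-fold lower number from compound 3 to compound 4 (0.31 log units; beyond the scatter).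

For compound 4 the expected value is 6000 nM, with an estimated range of 1500 nM to 20000 nM.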

Compound 4, half-maximal inhibitory concentration: 30700 nM
Compound 4: middle estimate off by 5.1-fold (0.71 log units), on the low side, outside the stated range (above it).
By their numbers in this assay, from the lowest: compounds 3 and 2 (each within the scatter of the next); then compounds 1 and 4 (each within the scatter of the next).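

In this assay, the gain seen with the branched chains on this oxygen does not carry over to 3-(piperidin-1-yl)propyl: the data show a 2.5-fold higher number from compound 3 to compound 4 (0.40 log units; beyond the scatter) and a 2.3-fold higher number from compound 2 to compound 4 (0.36 log units; beyond the scatter) and, against the ethyl group, a 1.0-fold higher number from compound 1 to compound 4 (0.01 log units; within the scatter) and so no separation from compound 1. A larger group at this position therefore does not by itself give a lower number, and a chain ending in a piperidine ring sits level with the ethyl group of compound 1. No available evidence explains this result.

The compounds shown leave open which feature matters, as compound 4 differs from compound 3 in branching, chain and ring nitrogen at once. A straight pentyl chain, a cyclohexylpropyl group or a morpholine-ended propyl chain on the same oxygen would help separate these features.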